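This account rests on a few compounds, and the source may have more. Where it says the series, first, only, none or still open, it means among the compounds named here.

Two compounds have values in an ADME assay on microsomes from liver (Homo sapiens) for metabolic stability, read by LC-MS, with a stated time of 4 h, tested at 1 uM (a higher number here means faster removal of the compound, a lower number slower removal), to start from.

- Compound 1 `Cc1cc(CNC(=O)Nc2cc(Cl)nc(OCC(F)F)c2)nnc1-c1cn(C)nc1C(F)(F)F` gives < 50 mL/min/kg as a limit.
- Compound 2 `CCOc1cc(NC(=O)NCc2cc(C)c(-c3cn(C)nc3C(F)(F)F)nn2)cc(C)n1` gives < 15 mL/min/kg as a limit.

Neither compound has an exact number. Compound 2 stands at < 15 mL/min/kg in this assay, and this value is a limit of the assay. Compound 1 stands at < 50 mL/min/kg in the same assay, and this value is also a limit. Among the measured compounds shown here, the two results cannot be set against each other as a measured step, and no pair of measured compounds differs in one place.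

Compound 3 `CCOc1nc(C)cc(NC(=O)NCc2cc(C)c(-c3cn(C)nc3C(F)(F)F)nn2)c1Cl` takes the 2-ethoxy-6-methylpyridin-4-yl group of compound 2 to a 3-chloro-2-ethoxy-6-methylpyridin-4-yl group. This places chloro in place of hydrogen on an aromatic carbon, ortho to an ethoxy group and para to a methyl group (chloro in place of hydrogen on an aromatic carbon). For the measured compounds named here, with no measured step to guide it, the expectation stays modest. The expected step that the limit leaves unreadable from compound 2 to compound 3 is no larger than the usual scatter, and the data favour no direction. For compound 3 the estimated clearance is 12 mL/min/kg, with an expected range from 6 mL/min/kg to 25 mL/min/kg in this assay.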

Compound 3, clearance: < 25 mL/min/kg
Compound 3: only a limit was reported; the forecaster's own chance of this, stated with the estimate: 60%; the middle value lies beyond the limit too.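

In this assay compound 3 gives < 25 mL/min/kg, which is a limit of the assay. The results for compound 2 and compound 3 are both limits, so no step can be read between them. The compounds shown leave open whether chloro in place of hydrogen on the aromatic carbon changes clearance at all, and in which direction.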